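A few compounds are considered here, and "the series" means these few. Any claim that something is new, unique, unknown or untested is made for them only; others in the source may bear on it.

Working notes on the series. Compound 1 `O=S(=O)(NCCCNc1nccc(-c2c(-c3cccc(F)c3)nc3sccn23)n1)c1cccc(F)c1` gives 8550 nM in a functional assay on SK-MEL-28 cells (Homo sapiens) for cytotoxicity, read by MTT assay; a lower number here means a stronger inhibitor, a higher number a weaker inhibitor. Compound 2 `O=C(NCCNc1nccc(-c2c(-c3cccc(F)c3)nc3sccn23)n1)c1c(F)cccc1F` gives 11400 nM in this assay, and compound 3 `COc1ccc(S(=O)(=O)NCCCNc2nccc(-c3c(-c4cccc(F)c4)nc4sccn34)n2)cc1` gives 8980 nM in this assay. The three numbers sit together: a 1.1-fold higher number from compound 1 to compound 3 (0.02 log units; within the scatter) and a 1.3-fold higher number from compound 1 to compound 2 (0.12 log units; within the scatter), so compound 3 stands among them with no separation beyond the scatter. Compound 4 `O=S(=O)(NCCCNc1nccc(-c2c(-c3cccc(F)c3)nc3sccn23)n1)c1ccc(Cl)cc1` differs from compound 3 by chloro in place of methoxy on an aromatic carbon. For the measured compounds named here, the one step that bears on this is the earlier exchange of the ring on the sulfonyl sulfur, a 1.1-fold higher number from compound 1 to compound 3 (0.02 log units; within the scatter), which moved nothing beyond the scatter. The step into compound 4 is therefore expected to be a 1.0-fold higher number from compound 3 to compound 4 (0.00 log units; within the scatter), with no direction beyond the scatter. Compound 4 is estimated at 9000 nM in this assay, within 4500 nM to 18000 nM.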

Compound 4, half-maximal inhibitory concentration: 8450 nM
The estimate for compound 4 lay 1.1-fold (0.03 log units) above the measured number; the range from low to high includes it.
By their numbers in this assay, from the lowest: compounds 4, 1, 3 and 2 (each within the scatter of the next).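

In this assay, chloro in place of methoxy on an aromatic carbon, para to a large group, gives a 1.1-fold lower number from compound 3 to compound 4 (0.03 log units; within the scatter) and so removes the one hydrogen-bond acceptor of the methoxy with no move beyond the scatter. 4-Chlorophenyl in place of 3-fluorophenyl on a sulfonyl sulfur gives a 1.0-fold lower number from compound 1 to compound 4 (0.01 log units; within the scatter) and the sulfonyl side chain in place of the 2,6-difluorophenyl carbonyl side chain gives a 1.3-fold lower number from compound 2 to compound 4 (0.13 log units; within the scatter) so all three steps stay within the scatter. Nothing available accounts for these flat steps.

Still open, as far as these compounds go, is whether an amine or a carboxylic acid at this ring position, or a longer chain, would separate from these numbers.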